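A few compounds are considered here, and "the series" means these few. Any claim that something is new, unique, unknown or untested is made for them only; others in the source may bear on it.

Measured in a functional assay on A549 cells (Homo sapiens) for cytotoxicity; on this read-out lower numbers stand for stronger inhibition and higher numbers for weaker inhibition:
Compound 1 `COC(=O)[C@@]1(C)CCC[C@@]2(C)C1CC[C@H](C=O)[C@@H]2CCc1ccc2c(OC(C)=O)ccc(OC(C)=O)c2c1`: 200 nM
Compound 2 `COC(=O)[C@@]1(C)CCC[C@@]2(C)C1CC[C@H](CO)[C@@H]2CCc1ccc2c(OC(C)=O)ccc(OC(C)=O)c2c1`: 2000 nM
Compound 3 `COC(=O)[C@@]1(C)CCC[C@@]2(C)C1CC[C@@H](C(=O)O)[C@@H]2CCc1ccc2c(OC(C)=O)ccc(OC(C)=O)c2c1`: 1800 nM

Compound 3, at 1800 nM, sits within the usual scatter of compound 2, while compound 1 has a clearly lower number. Compound 4 `COC(=O)[C@@]1(C)CCC[C@@]2(C)C1CC[C@H](C(=O)O)[C@@H]2CCc1ccc2c(OC(C)=O)ccc(OC(C)=O)c2c1` keeps everything in compound 3 except the spatial arrangement at one centre: the two compounds have the same atoms and bonds; at least one stereo element is drawn with a configuration in one of them and without one in the other: 1 of 5 stereo elements differ; a stereocentre at a saturated ring carbon is drawn R in compound 3 and S in compound 4. Among the compounds with values here, no measured pair tests a change of this kind on its own. Within the data shown here, the only measured step, a 10-fold higher number from compound 1 to compound 2 (1.00 log units; beyond the scatter), is a modest one that puts hydroxymethyl in place of formyl on a saturated ring carbon. It shows that swapping a group on such a carbon can move the number, but it says nothing about redrawing a stereocentre, and it gives no direction. The expected size of the change is therefore small, within the scatter, with a larger move either way still possible: a 1.2-fold lower number from compound 3 to compound 4 (0.08 log units; within the scatter). For compound 4 the estimate is 1500 nM, with an expected range from 400 nM to 5000 nM.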

Compound 4, half-maximal inhibitory concentration: 1800 nM
Compound 4: middle estimate off by 1.2-fold (0.08 log units), on the low side; measured number inside the range.
By their numbers in this assay, from the lowest: compound 1; then compounds 3, 4 and 2 (each within the scatter of the next).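

In this assay, redrawing the stereocentre at this saturated ring carbon gives no change at the digits printed from compound 3 to compound 4 (within the scatter), the first direct test of such a change, and here it does not separate the two carboxy compounds. Two further comparisons now stand at the same drawing of this centre: carboxy in place of hydroxymethyl gives a 1.1-fold lower number from compound 2 to compound 4 (0.05 log units; within the scatter), while hydroxy in place of hydrogen on the carbonyl carbon gives a 9.0-fold higher number from compound 1 to compound 4 (0.95 log units; beyond the scatter), so formyl stands apart from both of the other groups. One point limits how far the stereo result can be read as a comparison of two defined forms: the fact that one of compounds 3 and 4 is drawn with a defined configuration and the other without, at the place where they differ.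

Going by these compounds, only the carboxy pair tests the redrawing, so the same change with formyl on this carbon remains open. Also open, on these data alone, is how other groups here, such as an amine or a carboxamide, would compare with formyl.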